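Compound 3 to compound 4: acetyl for nitro

This account rests on a few compounds, and the source may have more. Where it says the series, first, only, none or still open, it means among the compounds named here.

Measured in an ADME assay on BHK cells (Mesocricetus auratus) for cytotoxicity, read by MTT assay, with a stated time of 96 h; on this read-out lower numbers stand for higher toxicity in this test and higher numbers for lower toxicity in this test (each entry is a limit and not a number):
- compound 1 `Fc1cccc(F)c1-c1nc2cc(C(F)(F)F)ccc2[nH]1` gives >= 100000 nM as a limit
- compound 2 `COc1ccc(-c2nc3cc([N+](=O)[O-])ccc3[nH]2)c(OC)c1` gives > 100000 nM as a limit
- compound 3 `COc1ccc(-c2nc3cc([N+](=O)[O-])ccc3[nH]2)c(OC)c1OC` gives > 100000 nM as a limit

Compound 3 stands at a limit. The series shows only the limit of > 100000 nM in this assay, at which 2 of the 3 values shown sit, and the limit of >= 100000 nM in this assay, at which 1 of the 3 values shown sits, and no number.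

Compound 4 `COc1ccc(-c2nc3cc(C(C)=O)ccc3[nH]2)c(OC)c1OC` carries acetyl in place of nitro on an aromatic carbon. For the measured compounds named here, the one measured step is a step that the two limits leave unreadable from compound 2 to compound 3 and gives no size to carry over. No step beyond the scatter is therefore expected in this assay for this change. The expected step is a number no higher from compound 3 to compound 4 (the limit leaves the size open) by estimate. For compound 4 the estimate is 100000 nM (expected range 30000 nM to 200000 nM).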

Compound 4, half-maximal cytotoxic concentration: > 100000 nM
Compound 4 ended at the assay's limit; the forecaster's own chance of this, stated with the estimate: 70%; the middle value sits exactly at the limit.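

No step can be read from compound 3 to compound 4 in this assay: both entries are limits and not numbers. The compounds shown leave open what actual number any of the four would give, and whether acetyl in place of nitro changes it.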